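Bromonaphthyl for Methoxyethylphenyl: Cytotoxicity Outlook

The source may hold more compounds than are shown below. What is called first, only, known or untested is meant among the compounds shown, and "the series" means these compounds.

Compound 1 `Cc1cc(C(C)C)ccc1OC(c1ccc(Cl)cc1)c1cnc(NC(=O)OC(C)(C)C)s1` gives a limit, not a number, in an ADME assay on HepG2 2.2.15 cells (Homo sapiens) for cytotoxicity; a higher number here means that more compound is tolerated, a lower number that less compound is tolerated: > 50000 nM.
Compound 2 `CC(C)(C)OC(=O)Nc1ncc(C(Oc2ccc(F)c(Cl)c2)c2ccc(Cl)cc2)s1` gives a limit in this assay: > 50000 nM.
Compound 3 `COCCc1ccc(OC(c2ccc(Cl)cc2)c2cnc(NC(=O)OC(C)(C)C)s2)cc1` also gives only a limit in this assay: > 50000 nM.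

Within the data shown here, every value so far sits at the same limit: the limit of > 50000 nM in this assay, at which 3 of the 3 values shown sit. Compound 3 therefore stands at that limit, with no number of its own. The steps a step that the two limits leave unreadable from compound 1 to compound 2, a step that the two limits leave unreadable from compound 1 to compound 3 and a step that the two limits leave unreadable from compound 2 to compound 3 cannot be read for size or direction. Compound 4 `CC(C)(C)OC(=O)Nc1ncc(C(Oc2ccc3cc(Br)ccc3c2)c2ccc(Cl)cc2)s1` differs from compound 3 by 6-bromonaphthalen-2-yl in place of 4-(2-methoxyethyl)phenyl on an oxygen on a saturated carbon. Among the measured compounds shown here, no measured step gives a readable size, so none is implied for this change. Compound 4 is expected to stay at the limit, which is a number no higher from compound 3 to compound 4 (the limit leaves the size open). The estimate for compound 4 is 50000 nM, between 20000 nM and 100000 nM.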

Compound 4, half-maximal cytotoxic concentration: > 50000 nM
Compound 4: a limit, no number; the forecaster's own chance of this, stated with the estimate: 70%; the middle value lies on the limit itself.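

Compound 4, like compound 1, compound 2 and compound 3, gives only a limit in this assay, so no step among them can be read for size or direction: the limit of > 50000 nM in this assay, at which 4 of the 4 values shown sit.

How much of any of these compounds the cells would need before a cytotoxic effect appears stays open, as does whether the groups on the oxygen differ at all.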